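Replacing the dimethylamino chain end with a larger nitrogen-rich group

The compounds below may be only part of what the source reports. "The series", "measured", "known", "first", "only" and "open" are said of these compounds alone.

Of the compounds shown here, two of a shared core have been measured in an assay on cells for inhibition of Voltage-dependent T-type calcium channel subunit alpha-1H (Homo sapiens), read by FLIPR and calcium flux, with stated times of 600 s and 300 s; on this read-out lower numbers stand for stronger inhibition and higher numbers for weaker inhibition. Compound 1 `CN(C)CCCOc1ccc(CN(C)c2nc3ccc(Oc4ccc(C(F)(F)F)cc4)cc3s2)cc1` gives 54000 nM, the lowest of the two numbers. Compound 2 `CN(Cc1ccc(OCCCN)cc1)c1nc2ccc(Oc3ccc(C#N)cc3)cc2s1` gives 328000 nM, a weaker result that differs from compound 1 at more than one place. Compound 3 `CN(Cc1ccc(OCCCNC(=N)N)cc1)c1nc2ccc(Oc3ccc(C(F)(F)F)cc3)cc2s1` carries a group of 4 heavy atoms (1 carbon, 3 nitrogen; no ring) in place of a group of 3 heavy atoms (2 carbon, 1 nitrogen; no ring), on a saturated chain carbon, three bonds along the chain from an oxygen on an aromatic ring. Within the data shown here, no single-change step among measured compounds guides this change. It is expected to move the number upward, by roughly a 1.9-fold higher number from compound 1 to compound 3 (0.27 log units; within the scatter), with wide uncertainty. Compound 3 is therefore estimated at 100000 nM, within a range from 30000 nM to 400000 nM.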

Compound 3, half-maximal inhibitory concentration: 212000 nM
Beside the measured number, compound 3's estimate is 2.1-fold (0.33 log units) below it; low and high end bracket the measured number.
By their numbers in this assay, from the lowest: compound 1; then compounds 3 and 2 (each within the scatter of the next).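

In this assay, exchanging the dimethylamino chain end for the larger nitrogen-rich group gives a 3.9-fold higher number from compound 1 to compound 3 (0.59 log units; beyond the scatter) at this place, on a saturated chain carbon, three bonds along the chain from an oxygen on an aromatic ring. Among these compounds, this is the first single-change step at this position, and it shows that inhibition here weakens with this change. No measurement available gives a reason for this shift.

On these data alone, whether a morpholine or a carboxylic acid at the chain end would move the number in the same direction remains open. So does the outcome of a longer chain carrying either of these end groups.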